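The compounds below may be only part of what the source reports. "The series", "measured", "known", "first", "only" and "open" are said of these compounds alone.

In a toxicity assay on L02 cells (Homo sapiens) for cytotoxicity, read by MTT assay, with a stated time of 72 h (on this read-out higher numbers stand for weaker inhibition and lower numbers for stronger inhibition), compound 1 `O=C1c2c[n+]([O-])c3ccccc3c2C(=O)c2c1c1ccccc1n2CCCCn1ccnc1` gives 150 nM, compound 2 `CCCCN1CCN(CCCCn2c3c(c4ccccc42)C(=O)c2c[n+]([O-])c4ccccc4c2C3=O)CC1` gives 5690 nM and compound 3 `CCCN1CCN(CCCCn2c3c(c4ccccc42)C(=O)c2c[n+]([O-])c4ccccc4c2C3=O)CC1` gives 6830 nM. Compound 3 therefore sits level with compound 2 and far from compound 1. Compound 4 `CN1CCN(CCCCCCn2c3c(c4ccccc42)C(=O)c2c[n+]([O-])c4ccccc4c2C3=O)CC1` rearranges the same atoms: 2-(4-methylpiperazin-1-yl)ethyl in place of 4-propylpiperazin-1-yl on a saturated chain carbon, four bonds along the chain from an aromatic nitrogen. The large 46-fold higher number from compound 1 to compound 3 (1.66 log units; beyond the scatter) replaced 1H-imidazol-1-yl, a swap compound 4 does not make. Closer is a 1.2-fold higher number from compound 2 to compound 3 (0.08 log units; within the scatter), a change on the piperazine that stayed within the scatter. For the measured compounds named here, no measured pair varies the linking chain, so the expected result is a 1.4-fold lower number from compound 3 to compound 4 (0.14 log units; within the scatter). For compound 4 the estimated value is 5000 nM, with an expected range of 1500 nM to 15000 nM.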

Compound 4, half-maximal inhibitory concentration: 3800 nM
Beside the measured number, compound 4's estimate is 1.3-fold (0.12 log units) above it, within the range that was stated.
By their numbers in this assay, from the lowest: compound 1; then compounds 4, 2 and 3 (each within the scatter of the next).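

Swapping 4-propylpiperazin-1-yl for 2-(4-methylpiperazin-1-yl)ethyl keeps the same atoms but sets the piperazine further along the chain, yet the change stays within the scatter (a 1.8-fold lower number from compound 3 to compound 4 (0.25 log units; within the scatter)), as does the swap from 4-butylpiperazin-1-yl (a 1.5-fold lower number from compound 2 to compound 4 (0.18 log units; within the scatter)). Rearranging these carbons therefore leaves the piperazine compounds level, while the gap to the imidazole remains large (a 25-fold higher number from compound 1 to compound 4 (1.40 log units; beyond the scatter)). No supporting measurement accompanies this result to explain it. Open, from the compounds shown here alone, is whether 1H-imidazol-1-yl on a longer chain would keep its low number, and whether a morpholine would sit with the piperazines or with compound 1.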